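The source may report more compounds than this note shows. Statements on the series, on what has been measured and on what is new or still open speak of the compounds shown alone.

Of the compounds shown here, three built on one shared core have been tested in a functional assay on the whole organism (strain C57BL/6J) for inhibition, with Mus musculus as the target, read by mobility shift assay and paw edema, with stated times of 30 min, 74 h and 2 h, at a dose of 10 mg/kg by the intraperitoneal route; on this read-out lower numbers stand for less inhibition and higher numbers for more inhibition at the one dose given (going by the name of the read-out). Compound 1 `O=C(NCc1ccc(CNS(=O)(=O)c2cccc(C(F)(F)F)c2)cc1)c1ccc(F)cc1` gives 20%, compound 2 `O=C(NCc1ccc(CNS(=O)(=O)c2cccc(Cl)c2)cc1)c1ccc(F)cc1` gives 20%, and compound 3 `O=C(NCc1ccc(CNS(=O)(=O)c2ccc(CN3CCCC3)cc2)cc1)c1ccc(F)cc1` gives 20%, so compound 3 stands level with both at the digits shown. For the measured compounds named here, the only measured step, no change at the digits printed from compound 1 to compound 2 (within the scatter), lies at a different place, on an aromatic carbon, and stayed within the scatter. Compound 4 `Cc1ccc(S(=O)(=O)NCc2ccc(CNC(=O)c3ccc(F)cc3)cc2)cc1` differs from compound 3 by hydrogen in place of pyrrolidin-1-yl on a saturated chain carbon bound to an aromatic carbon. Going by the values given here, no measured step touches that saturated chain carbon, so the one comparison at hand bears on it only loosely, and among the three measured compounds no change moved the read-out beyond the scatter. Compound 4 is therefore expected to show no change at the digits printed from compound 3 to compound 4 (within the scatter) in this assay. The estimate for compound 4 is 20%, with a range from 5% to 35%.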

Compound 4, a percentage reported as inhibition, in the whole organism at one dose (the size of the read-out at that dose, not a potency): 30%
Estimate against measurement, compound 4: 10 percentage points below; the range from low to high includes it.
By their numbers in this assay, from the lowest: compounds 1, 2, 3 and 4 (each within the scatter of the next).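

In this assay, hydrogen in place of pyrrolidin-1-yl on the saturated chain carbon bound to an aromatic carbon gives a number 10 percentage points higher from compound 3 to compound 4 (within the scatter), so even losing this whole ring does not move the read-out beyond the scatter. On the sulfonyl sulfur, 4-methylphenyl gives a number 10 percentage points higher from compound 2 to compound 4 (within the scatter) in place of 3-chlorophenyl and a number 10 percentage points higher from compound 1 to compound 4 (within the scatter) in place of 3-(trifluoromethyl)phenyl. No supporting data bear on these results. Going by these compounds, whether a carboxylic acid, a morpholine or a longer chain on that saturated chain carbon would change the read-out beyond the scatter remains open.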